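Extending the alkyl group on the ring nitrogen of compound 3

The source may report more compounds than this note shows. Statements on the series, on what has been measured and on what is new or still open speak of the compounds shown alone.

Of the compounds shown here, three carrying a shared cyclohexylcarbamate side chain have been measured in an assay on isolated protein for inhibition of Fatty-acid amide hydrolase 1 (Homo sapiens), read by fluorescence, with a stated time of 30 min; on this read-out lower numbers stand for stronger inhibition and higher numbers for weaker inhibition. Compound 1, `CCOC(=O)c1cc(-c2cccc(OC(=O)NC3CCCCC3)c2)n(-c2ccc(C)cc2)n1`, gives 29 nM. Compound 2, `CCN(CC)C(=O)c1cc(-c2cccc(OC(=O)NC3CCCCC3)c2)n(-c2ccccc2)n1`, gives 448 nM. Compound 3, `CCOC(=O)c1cc(-c2cccc(OC(=O)NC3CCCCC3)c2)nn1C`, gives 227 nM. Among these three numbers compound 3 stands second highest: its value and that of compound 2 lie within the usual scatter of each other, so nothing can be said about their order, while the value of compound 1 is far enough below that of compound 3 to lie beyond the scatter.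

Compound 4, `CCOC(=O)c1cc(-c2cccc(OC(=O)NC3CCCCC3)c2)nn1CC`, has not yet been measured. It differs from compound 3 in one place: methyl in place of hydrogen on a saturated chain carbon bound to an aromatic nitrogen, so that the group on the aromatic nitrogen is read as methyl to ethyl. Within the data shown here, no measured pair in this set isolates such a change, so the expectation rests on compound 3 alone. The step from compound 3 to compound 4 in this assay is estimated to be small, if anything towards a lower number, and may well remain within the scatter, giving an expected 1.4-fold lower number from compound 3 to compound 4 (0.15 log units; within the scatter). On that basis compound 4 is expected to give 160 nM in this assay, with a range from 60 nM to 500 nM.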

Compound 4, half-maximal inhibitory concentration: 507 nM
Compound 4: the middle estimate sits 3.2-fold (0.50 log units) below what was measured, outside the stated range (above it).
By their numbers in this assay, from the lowest: compound 1; then compounds 3, 2 and 4 (each within the scatter of the next, the first and the last beyond it).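

In this assay, the group on the aromatic nitrogen proves sensitive to even a single added carbon: going from methyl to ethyl gives a 2.2-fold higher number from compound 3 to compound 4 (0.35 log units; beyond the scatter), a modest step towards weaker inhibition. Among these compounds, the earlier compounds offered no pair differing in only one place, so this is the first change at this position that can be read on its own, and it shows that the position does not accept this extension without a loss, at least with the ethyl ester kept in place. Nothing among the data shown accounts for the step, which therefore stands as an observation without an explanation.

A single step cannot show whether the number keeps rising along a series or whether this is an isolated effect, and a longer chain such as propyl, a branched group such as isopropyl or a chain ending in an amine would be needed to tell. Also open, going by these compounds, is how the parent with hydrogen on the aromatic nitrogen compares with compound 3, which would show whether the methyl group itself helps or hinders inhibition.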